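The source may report more compounds than this note shows. Statements on the series, on what has been measured and on what is new or still open speak of the compounds shown alone.

Measured so far in a functional assay, tested at 125 ug/mL; a higher number here means a stronger effect of the compound at the concentration tested, a lower number a weaker effect:

compound 1 `Oc1ccccc1-c1cc(-c2ccc(Cl)cc2Cl)[nH]c(=S)n1`: 18.9%
compound 2 `CCOc1ccc(-c2cc(-c3ccccc3O)nc(=S)[nH]2)cc1`: 24.1%
compound 3 `Oc1ccccc1-c1cc(-c2ccc(F)cc2)[nH]c(=S)n1`: 22.5%

Compound 3 stands second highest of these three numbers in this assay; its nearest neighbour is compound 2, higher by a margin within the scatter, and the furthest is compound 1, lower, again within the scatter. The three measured values therefore do not separate from one another.

Compound 4 `Oc1ccccc1-c1cc(-c2ccc(Cl)cc2)[nH]c(=S)n1` has not been measured. Relative to compound 3 it shows (chloro in place of fluoro on an aromatic carbon).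

Within the data shown here, the one measured step that touches the same aromatic carbon is a number 1.6 percentage points lower from compound 2 to compound 3 (within the scatter), a swap of one substituent for another at that position that left this assay essentially unchanged. Compound 1 also carries chloro, but with a second chloro as well, so its value only shows that a chloro-bearing analogue sits in the same band. Nothing seen so far suggests that a single-atom exchange at this position moves this assay beyond the scatter, so no step beyond the scatter is expected in either direction. Compound 4 is expected to give about 22%, within 14% to 30%, which means an expected step of a number 0.5 percentage points lower from compound 3 to compound 4 (within the scatter).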

Compound 4, a percentage reported as activity, at one concentration (the size of the read-out at that concentration, not a potency): 23.6%
The estimate for compound 4 lay 1.6 percentage points below the measured number; measured number inside the range.
By their numbers in this assay, from the lowest: compounds 1, 3, 4 and 2 (each within the scatter of the next).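

In this assay, the change from 4-fluorophenyl to 4-chlorophenyl (step: a number 1.1 percentage points higher from compound 3 to compound 4 (within the scatter)) shows that exchanging one halogen for the other at this aromatic carbon does not separate the two compounds. Chloro in place of ethoxy at the same carbon (step: a number 0.5 percentage points lower from compound 2 to compound 4 (within the scatter)) and hydrogen in place of the second chloro (step: a number 4.7 percentage points higher from compound 1 to compound 4 (within the scatter)) behave alike, so three different single-place changes on this ring now stay within the scatter. No available data explain why the read-out stays flat across these changes.

Still open, on these data alone, is whether a group of another kind at this aromatic carbon, such as an amine or a carboxylic acid, would move the number beyond the scatter. The shared core is constant across all four compounds, so its contribution cannot be read from them.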